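Working notes: the step from compound 2 to compound 3

A few compounds are considered here, and "the series" means these few. Any claim that something is new, unique, unknown or untested is made for them only; others in the source may bear on it.

Values in a functional assay on NCI-H460 cells (Homo sapiens) for inhibition, read by MTT assay, with a stated time of 72 h (a lower number here means a stronger inhibitor, a higher number a weaker inhibitor), so far
- compound 1 `COc1cc(NC(C)CCCNC(=O)Nc2ccc(F)cc2)c2ncccc2c1` gives 26000 nM
- compound 2 `COc1cc(NC(C)CCCNC(=O)Nc2ccc(Cl)cc2)c2ncccc2c1` gives 34000 nM

Compound 2 at 34000 nM stands within the scatter of compound 1, so the pair cannot be ranked. The next compound to be read is compound 3 `COc1cc(NC(C)CCCNC(=O)NNC(=O)Nc2ccc(O)cc2)c2ncccc2c1`, and the structural change is large: ((4-hydroxyphenyl)carbamoyl)amino in place of 4-chlorophenyl on an amide-type nitrogen. In short, ((4-hydroxyphenyl)carbamoyl)amino comes in place of 4-chlorophenyl on an amide-type nitrogen. Going by the values given here, only one measured step exists, a 1.3-fold higher number from compound 1 to compound 2 (0.12 log units; within the scatter), and it is a swap of chloro for fluoro on an aromatic carbon. That step stays within the scatter, but it covers a far smaller change and offers little guide here. Among the compounds with values here, no measured compound carries the entering group, so the direction is poorly defined and the range must stay wide. In this assay a modest move toward a lower number is expected, as a judgement and not a measured trend. The expected step is a 1.9-fold lower number from compound 2 to compound 3 (0.28 log units; within the scatter), and it may not clear the scatter. For compound 3 the estimated value is 18000 nM, with an expected range from 4000 nM to 70000 nM.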

Compound 3, half-maximal inhibitory concentration: > 100000 nM
Compound 3 gave a limit, no number (the forecaster's own chance of this, stated with the estimate: 20%); at least 5.5-fold (0.74 log units) between middle value and limit.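

In this assay compound 3 gives > 100000 nM, which is a limit of the assay and not a number: the limit of > 100000 nM in this assay, at which 1 of the 3 values shown sits.

On the amide-type nitrogen, ((4-hydroxyphenyl)carbamoyl)amino in place of 4-chlorophenyl gives an at least 2.9-fold higher number from compound 2 to compound 3 (0.46 log units; beyond the scatter) and in place of 4-fluorophenyl gives an at least 3.8-fold higher number from compound 1 to compound 3 (0.58 log units; beyond the scatter); both steps lie beyond the scatter, whereas the swap of chloro for fluoro, a 1.3-fold higher number from compound 1 to compound 2 (0.12 log units; within the scatter), stays within it. The earlier pair showed no measurable response to a change of halogen on the aromatic ring, while this larger change at the same nitrogen moves the number upward, so the series does respond at this position, and only a lower bound on the size of that response is available.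

As far as these compounds go, it remains open whether the rise in the number follows from the added carbamoyl-amino link or from the hydroxy group on the aromatic ring, as compound 3 changes both at once. Also open, from the compounds shown here alone, is how a simple 4-hydroxyphenyl, or a 4-aminophenyl or 4-carboxyphenyl, on the same nitrogen would read against compound 1 and compound 2.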